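Working notes: cytotoxicity across four related compounds

The compounds below may be only part of what the source reports. "The series", "measured", "known", "first", "only" and "open" are said of these compounds alone.

Measured so far in an ADME assay on Vero 76 cells (Chlorocebus sabaeus) for cytotoxicity, read by MTT assay, with a stated time of 96 h; on this read-out lower numbers stand for higher toxicity in this test and higher numbers for lower toxicity in this test:
compound 1, `NS(=O)(=O)c1ccc(N2N=C(c3ccc(OCc4ccccc4)cc3)CC2c2ccc(Cl)cc2)cc1`, 82000 nM
compound 2, `NS(=O)(=O)c1ccc(N2N=C(c3ccc(OCc4ccccc4)cc3)CC2c2ccccc2F)cc1`, > 100000 nM
compound 3, `NS(=O)(=O)c1ccc(N2N=C(c3ccc(Oc4ccccc4)cc3)CC2c2ccccc2F)cc1`, 96000 nM

Compound 2 gives only a limit in this assay, > 100000 nM, which is the limit of > 100000 nM in this assay, at which 1 of the 3 values shown sits. Compound 1 and compound 3 both give numbers, and the two numbers sit within the usual scatter of each other, so no order between them can be read.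

Two changes connect the measured compounds. From compound 2 to compound 1 the change is 4-chlorophenyl in place of 2-fluorophenyl on a saturated ring carbon, and the step is an at least 1.2-fold lower number from compound 2 to compound 1 (0.08 log units; that floor lies within the scatter). From compound 2 to compound 3 the change is phenyl in place of benzyl on an oxygen on an aromatic ring, and the step is an at least 1.0-fold lower number from compound 2 to compound 3 (0.01 log units; that floor lies within the scatter). Both steps start from a limit, so each is only a floor, and each floor lies within the scatter.

Compound 4, `NS(=O)(=O)c1ccc(N2N=C(c3ccc(Oc4ccccc4)cc3)CC2c2ccc(Cl)cc2)cc1`, is not yet measured in this assay. It differs from compound 3 by 4-chlorophenyl in place of 2-fluorophenyl on a saturated ring carbon. This is the same change as from compound 2 to compound 1, made here on the core that carries phenoxy rather than benzyloxy. The earlier step gives no sign of a shift beyond the scatter, so compound 4 is expected to sit close to compound 3, with an estimated step of a 1.2-fold lower number from compound 3 to compound 4 (0.08 log units; within the scatter) in this assay. The estimate for compound 4 in this assay is 80000 nM, expected to fall between 40000 nM and 160000 nM.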

Compound 4, half-maximal cytotoxic concentration: 88000 nM
Compound 4: middle estimate off by 1.1-fold (0.04 log units), on the low side, within the range that was stated.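

In this assay, 4-chlorophenyl in place of 2-fluorophenyl on a saturated ring carbon gives a 1.1-fold lower number from compound 3 to compound 4 (0.04 log units; within the scatter), and phenyl in place of benzyl on an oxygen on an aromatic ring gives a 1.1-fold higher number from compound 1 to compound 4 (0.03 log units; within the scatter). The first change stays within the scatter on the phenoxy core, but its step on the benzyloxy core starts from a limit, so close agreement between the two cores is not shown: the same change on two cores in this assay, an at least 1.2-fold lower number (0.08 log units; that floor lies within the scatter) from compound 2 to compound 1 and a 1.1-fold lower number (0.04 log units; within the scatter) from compound 3 to compound 4; the limit leaves it open whether they differ The second change likewise stays within the scatter between the two numbers measured with 4-chlorophenyl, while its step with 2-fluorophenyl also starts from a limit, so these compounds show no sign of a shift beyond the scatter but do not establish that either change carries over unaltered: the same change on two cores in this assay, an at least 1.0-fold lower number (0.01 log units; that floor lies within the scatter) from compound 2 to compound 3 and a 1.1-fold higher number (0.03 log units; within the scatter) from compound 1 to compound 4; the limit leaves it open whether they differ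

The compounds shown leave open what happens with groups of another kind, such as an amine or a carboxylic acid on the phenyl ring at the saturated ring carbon, or a longer chain in place of benzyl on the oxygen. With only these two groups at each place, no step beyond the scatter appears, and whether any change in this series can produce one in this assay remains an open question.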